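The source may report more compounds than this note shows. Statements on the series, on what has been measured and on what is new or still open speak of the compounds shown alone.

Measured compounds:
- compound 1, `c1cc2ncc(-c3nn[nH]n3)cc2cc1OC1CCCCC1`: 5 mg/kg
- compound 2, `O=C(O)c1cnc2ccc(OC3CCCCC3)cc2c1`: > 25 mg/kg
- compound 3, `Cc1cc(F)c2[nH]cc(-c3nn[nH]n3)c(=O)c2c1`: 2.5 mg/kg

In a functional assay on the whole organism (strain Sprague-Dawley) for inhibition, with Rattus norvegicus as the target (a lower number here means that less compound is needed, a higher number that more compound is needed for the effect), compound 1 gives 5 mg/kg and compound 3 gives 2.5 mg/kg; the two lie within the usual scatter of each other, so neither can be set above the other. For compound 2 the value > 25 mg/kg is a limit of the assay rather than a number. Compound 4, `c1ccc2ncc(-c3nn[nH]n3)cc2c1`, differs from compound 1 in one place: hydrogen in place of cyclohexyloxy on an aromatic carbon. Going by the values given here, the only measured step, an at least 5.0-fold higher number from compound 1 to compound 2 (0.69 log units; beyond the scatter), exchanges the acidic group while the cyclohexyloxy stays in place, so it does not bear on this change, and no measured pair shows what removing the cyclohexyloxy does. With nothing to lean on, the estimate stays wide. Compound 4 is expected to need more than compound 1, an expected step of a 3.0-fold higher number from compound 1 to compound 4 (0.48 log units; beyond the scatter). Compound 4 is therefore estimated at 15 mg/kg, in a range from 4 mg/kg to 50 mg/kg; because of the limit of > 25 mg/kg in this assay, at which 1 of the 3 values shown sits, a weaker compound may again show only a limit.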

Compound 4, minimum effective dose: 10 mg/kg
Compound 4: the middle estimate sits 1.5-fold (0.18 log units) above what was measured; the range from low to high includes it.
By their numbers in this assay, from the lowest: compounds 3, 1 and 4 (each within the scatter of the next, the first and the last beyond it). At a limit, above all of these: compound 2.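

In this assay, replacing cyclohexyloxy with hydrogen on this aromatic carbon gives a 2.0-fold higher number from compound 1 to compound 4 (0.30 log units; within the scatter), the first measured view of this position. The whole cyclohexyloxy group, with its non-aromatic ring, can therefore be removed without a change that stands out from the scatter, whereas exchanging the 2H-tetrazol-5-yl group for carboxy gives an at least 5.0-fold higher number from compound 1 to compound 2 (0.69 log units; beyond the scatter). Compound 4 gives a number, and compound 2 alone stays at a limit of the assay: the limit of > 25 mg/kg in this assay, at which 1 of the 4 values shown sits.

As far as these compounds go, whether a smaller group such as methoxy, or an amine, would behave like hydrogen or like cyclohexyloxy at this carbon remains open. From the compounds shown here alone, it is also open whether hydrogen at this position would give a similar reading on a compound carrying a carboxy group instead of 2H-tetrazol-5-yl.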